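The source may report more compounds than this note shows. Statements on the series, on what has been measured and on what is new or still open speak of the compounds shown alone.

Measured so far:
compound 1, `O=C(CCCCCCCc1cn(-c2ccccc2-c2ccccc2)nn1)Nc1ccncc1`, 82%
compound 2, `O=C(/C=C/c1cccnc1)NCCCCCc1cn(-c2ccccc2-c2ccccc2)nn1`, 32%

In a functional assay on SH-SY5Y cells (Homo sapiens) for cytotoxicity, read by MTT assay, with a stated time of 48 h, tested at 1 uM (a lower number here means a stronger effect, a higher number a weaker effect of the compound at the concentration tested), compound 2 stands lowest of the two numbers; its nearest neighbour is compound 1, with a number 50 percentage points lower from compound 1 to compound 2 (beyond the scatter). Compound 3, `O=C(Cc1cccnc1)NCCCCCc1cn(-c2ccccc2-c2ccccc2)nn1`, is not yet measured. It differs from compound 2 by (pyridin-3-yl)methyl in place of 2-(pyridin-3-yl)ethenyl on a carbonyl carbon.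

Among the measured compounds shown here, the only measured step, a number 50 percentage points lower from compound 1 to compound 2 (beyond the scatter), exchanges the whole pyridine-bearing amide portion at once and so bears on the region touched here, but it does not isolate the double bond that is removed in compound 3. For the measured compounds named here, the data give no step that tests this change by itself. Going by the values given here, with no direct precedent, a moderate loss toward a higher number seems the most likely outcome, as compound 3 keeps the chain length and pyridine of compound 2 but not its ethenyl link. In this assay compound 3 is therefore expected near 50%, within 25% to 80%, a step of a number 18 percentage points higher from compound 2 to compound 3 (beyond the scatter) expected from compound 2.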

Compound 3, a percentage reported as activity, at one concentration (the size of the read-out at that concentration, not a potency): 99%
Compound 3: middle estimate off by 49 percentage points, on the low side; measured number above the stated range.
By their numbers in this assay, from the lowest: compound 2; then compound 1; then compound 3.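

In this assay, the exchange of 2-(pyridin-3-yl)ethenyl for (pyridin-3-yl)methyl on the carbonyl carbon gives a number 67 percentage points higher from compound 2 to compound 3 (beyond the scatter), so this one place alone, with the rest of compound 2 unchanged, carries a large difference that the earlier whole-portion exchange could not isolate. The other new step, a number 17 percentage points higher from compound 1 to compound 3 (beyond the scatter), is modest by comparison, which shows that a pyridine-bearing amide portion on this chain does not by itself give a low number. Nothing available explains the size of either step.

The change removes the double bond and shortens the link together, so the compounds shown leave open which of the two matters. A 2-(pyridin-3-yl)ethyl group on the same carbonyl carbon would separate them.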